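From 4-chlorophenyl to 4-bromophenyl: expectation for compound 3

The compounds below may be only part of what the source reports. "The series", "measured", "known", "first", "only" and "open" are said of these compounds alone.

In a functional assay on K562 cells (Homo sapiens) for cytotoxicity, read by MTT assay, with a stated time of 24 h (a higher number here means a weaker inhibitor, a lower number a stronger inhibitor), compound 1 (`CN1C/C(=C\c2ccc(C#N)cc2)C(=O)/C(=C/c2ccccc2F)C1`) gives 2670 nM and compound 2 (`CN1C/C(=C\c2ccc(Cl)cc2)C(=O)/C(=C/c2ccc(C#N)cc2)C1`) gives 13300 nM as the higher number of the two, which marks the weaker inhibitor. Compound 3 (`CN1C/C(=C\c2ccc(Br)cc2)C(=O)/C(=C/c2ccc(C#N)cc2)C1`), not yet measured, differs from compound 2 by bromo in place of chloro on an aromatic carbon, para to a large group (bromo in place of chloro on an aromatic carbon). Going by the values given here, the only measured step is a 5.0-fold higher number from compound 1 to compound 2 (0.70 log units; beyond the scatter) and it is modest. That step puts 4-chlorophenyl in place of 2-fluorophenyl, a different change, so it bears only loosely on this one. Among the compounds with values here, no measured pair exchanges chloro for bromo. The step expected in this assay is a 1.1-fold lower number from compound 2 to compound 3 (0.04 log units; within the scatter) and so none beyond the scatter. Compound 3 is expected at 12000 nM with a range from 6000 nM to 25000 nM in this estimate.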

Compound 3, half-maximal inhibitory concentration: 7420 nM
Compound 3: the middle estimate sits 1.6-fold (0.21 log units) above what was measured; the range from low to high includes it.
By their numbers in this assay, from the lowest: compound 1; then compounds 3 and 2 (each within the scatter of the next).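

Exchanging chloro for bromo on an aromatic carbon, para to a large group, gives a 1.8-fold lower number from compound 2 to compound 3 (0.25 log units; within the scatter) in this assay, so this exchange does not separate the two compounds. Putting 4-bromophenyl in place of 2-fluorophenyl gives a 2.8-fold higher number from compound 1 to compound 3 (0.44 log units; beyond the scatter), so the separation first seen with 4-chlorophenyl remains beyond the scatter with a second halo group. No measurement shown here accounts for either step.

From the compounds shown here alone, whether a group of another kind at this place, such as a methoxy group or an amine, would move the number beyond the scatter remains open. The compounds shown also do not tell whether the separation from compound 1 follows the fluoro group itself or its place on the ring.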